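The compounds below may be only part of what the source reports. "The series", "measured", "known", "first", "only" and "open" are said of these compounds alone.

Going by the values given here, in an ADME assay on microsomes from liver (Rattus norvegicus) for metabolic stability, read by LC-MS, using NADPH, with a stated time of 30 min, tested at 1 uM (a lower number here means slower removal, a higher number faster removal of the compound), three compounds built on one shared core have numbers so far: compound 1 `CC(C)c1noc(N2CCC(Oc3cc(N4CCc5cc(C6CCCCC6=O)ccc54)ncn3)CC2)n1` gives 141 mL.min-1.g-1, compound 2 `CC(C)c1noc(N2CCC(Oc3cc(N4CCc5cc(N6CCCNS6(=O)=O)ccc54)ncn3)CC2)n1` gives 21 mL.min-1.g-1 and compound 3 `CC(=O)N(C)c1ccc2c(c1)CCN2c1cc(OC2CCN(c3nc(C(C)C)no3)CC2)ncn1` gives 17 mL.min-1.g-1. Two of these sit together, with a 1.2-fold lower number from compound 2 to compound 3 (0.09 log units; within the scatter), and the gap to the third is real, with an 8.3-fold lower number from compound 1 to compound 3 (0.92 log units; beyond the scatter). Compound 4 `CC(C)c1noc(N2CCC(Oc3cc(N4CCc5cc(N6CCC(O)CC6=O)ccc54)ncn3)CC2)n1` carries 4-hydroxy-2-oxopiperidin-1-yl in place of acetyl(methyl)amino on an aromatic carbon. The nearest guide is the swap of a carbon-only ring for a ring with hetero atoms, which gave a 6.7-fold lower number from compound 1 to compound 2 (0.83 log units; beyond the scatter). Compound 4 also has a ring with a hetero atom, so a step beyond the scatter is not expected, and the estimated step is a 1.3-fold higher number from compound 3 to compound 4 (0.11 log units; within the scatter). Compound 4 is expected at 22 mL.min-1.g-1, within a range of 10 mL.min-1.g-1 to 50 mL.min-1.g-1.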

Compound 4, intrinsic clearance in microsomes: 13 mL.min-1.g-1
For compound 4 the middle estimate is 1.7-fold (0.23 log units) above the measured one; the measured number falls inside the stated range.
By their numbers in this assay, from the lowest: compounds 4, 3 and 2 (each within the scatter of the next); then compound 1.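

In this assay, 4-hydroxy-2-oxopiperidin-1-yl on this aromatic carbon stands level with acetyl(methyl)amino, with a 1.3-fold lower number from compound 3 to compound 4 (0.12 log units; within the scatter), and with the ring of compound 2, with a 1.6-fold lower number from compound 2 to compound 4 (0.21 log units; within the scatter). A third, differently built group thus joins the low set, and a six-membered ring here does not by itself bring the high number of 2-oxocyclohexyl, with an 11-fold lower number from compound 1 to compound 4 (1.04 log units; beyond the scatter). Nothing given here offers a reason for these numbers. From the compounds shown here alone, whether a simple amine or a carboxylic acid on this carbon would stay with compound 2, compound 3 and compound 4 remains open, as does what the hydroxy group contributes on its own.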